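A Methylphenyl Triazole Ester on the Shared Core

This account rests on a few compounds, and the source may have more. Where it says the series, first, only, none or still open, it means among the compounds named here.

Compound 1: `C/C(=C\CC/C(C)=C/CC[C@@H]1[C@@]2(C)CCC(=O)C(C)(C)[C@H]2CC[C@@]1(C)O)CC/C=C(\C)C(=O)OCc1cn(-c2ccc(F)cc2)nn1`; in a functional assay on DU-145 cells (Homo sapiens) for antiproliferative activity, read by MTT assay, with a stated time of 48 h (a lower number here means a stronger inhibitor, a higher number a weaker inhibitor), compound 1 gives > 150000 nM, which is a limit of the assay and not a number.
Compound 2: `C/C(=C\CC/C(C)=C/CC[C@@H]1[C@@]2(C)CCC(=O)C(C)(C)[C@H]2CC[C@@]1(C)O)CC/C=C(\C)C(=O)OCc1cn(-c2ccc([N+](=O)[O-])cc2)nn1`; in this assay compound 2 gives > 150000 nM, again only a limit.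
Compound 3: `C/C(=C\CC/C(C)=C/CC[C@@H]1[C@@]2(C)CCC(=O)C(C)(C)[C@H]2CC[C@@]1(C)O)CC/C=C(\C)C(=O)OCc1cn(-c2ccccc2[N+](=O)[O-])nn1`; in this assay compound 3 gives > 150000 nM, likewise a limit.

Compound 2 therefore stands where every value shown stands, at the limit of > 150000 nM in this assay, at which 3 of the 3 values shown sit. Three single-point steps connect the measured compounds, a step that the two limits leave unreadable from compound 1 to compound 2, a step that the two limits leave unreadable from compound 1 to compound 3 and a step that the two limits leave unreadable from compound 2 to compound 3, and none of them can be read; both ends of each sit at the limit. Compound 4, `C/C(=C\CC/C(C)=C/CC[C@@H]1[C@@]2(C)CCC(=O)C(C)(C)[C@H]2CC[C@@]1(C)O)CC/C=C(\C)C(=O)OCc1cn(-c2cccc(C)c2)nn1`, has not yet been measured. It differs from compound 2 in one place: 3-methylphenyl in place of 4-nitrophenyl on an aromatic nitrogen. The three unreadable steps all swap one aryl group on the same aromatic nitrogen without moving any compound off the limit, and nothing measured points to a different outcome for this swap. The step from compound 2 to compound 4 is thus expected to be a step that the limit leaves unreadable from compound 2 to compound 4, no change that can be read. In this assay compound 4 is estimated at 200000 nM, with a range from 100000 nM to 400000 nM, most likely reported only as a limit once more.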

Compound 4, half-maximal inhibitory concentration: 137000 nM
For compound 4 the middle estimate is 1.5-fold (0.16 log units) above the measured one; the range from low to high includes it.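

In this assay compound 4 gives 137000 nM, the only number rather than a limit among the compounds shown with an aryl group at this aromatic nitrogen. The change to 3-methylphenyl gives an at least 1.0-fold lower number from compound 2 to compound 4 (0.03 log units; that floor lies within the scatter), an at least 1.0-fold lower number from compound 3 to compound 4 (0.03 log units; that floor lies within the scatter) and an at least 1.0-fold lower number from compound 1 to compound 4 (0.03 log units; that floor lies within the scatter), so each step is known only as a floor, and none is shown to exceed the scatter. Compound 4 therefore sits just on the readable side, while the other three compounds remain at a limit that is not a number: the limit of > 150000 nM in this assay, at which 3 of the 4 values shown sit.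

From the compounds shown here alone, the full size of these steps remains unknown, and the steps among compound 1, compound 2 and compound 3 still cannot be read. Also open, going by these compounds, is what an amine or a carboxylic acid in place of the methyl of 3-methylphenyl would give in this assay.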